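The compounds below may be only part of what the source reports. "The series", "measured", "known", "first", "only" and "open" are said of these compounds alone.

Measured so far:
compound 1, `CS(=O)(=O)Cc1cccc2c1CCC2c1ncc[nH]1`, gives 70%
compound 2, `CCOCc1cccc2c1CCC2c1ncc[nH]1`, gives 64%

Both compounds share one core and differ only in the group on a saturated chain carbon bound to an aromatic carbon. In a functional assay on CHO cells for agonist activity at Alpha-1A adrenergic receptor (Homo sapiens), read by fluorescence and calcium flux (on this read-out lower numbers stand for smaller maximal responses and higher numbers for larger maximal responses), compound 1 gives 70%, and compound 2 gives 64%. Among the compounds with values here, compound 2 stands lowest of the two numbers, but its nearest neighbour is compound 1 and the one step between them, a number 6 percentage points lower from compound 1 to compound 2 (within the scatter), lies within the scatter, so the two cannot be told apart on these numbers.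

Compound 3, `COCCc1cccc2c1CCC2c1ncc[nH]1`, has not been measured in this assay. It differs from compound 2 as follows: methoxymethyl in place of ethoxy on a saturated chain carbon bound to an aromatic carbon. Within the data shown here, the only measured step that bears on this, a number 6 percentage points lower from compound 1 to compound 2 (within the scatter), sits at the same place and exchanged a larger group without moving the number beyond the scatter. The change from compound 2 to compound 3 keeps the same atoms and only joins them differently, so compound 3 is expected to stay close to compound 2, with a step of no change at the digits printed from compound 2 to compound 3 (within the scatter) that is not expected to exceed the scatter. For compound 3 the estimate in this assay is 64%, within a range from 50% to 78%.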

Compound 3, largest response reached (Emax), in percent of the reference or control that the assay uses in the Alpha-1A adrenergic receptor assay: 50%
Beside the measured number, compound 3's estimate is 14 percentage points above it; the range from low to high includes it.
By their numbers in the Alpha-1A adrenergic receptor assay, from the lowest: compound 3; then compounds 2 and 1 (each within the scatter of the next).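

In the Alpha-1A adrenergic receptor assay the exchange of ethoxymethyl for 2-methoxyethyl gives a number 14 percentage points lower from compound 2 to compound 3 (beyond the scatter) even though both compounds hold the same atoms, so at this place, on a saturated chain carbon bound to an aromatic carbon, the way those atoms are joined can matter and not only which atoms are present. Within the data shown here, the earlier comparison suggested a tolerant position, since the Alpha-1A adrenergic receptor assay gave only a number 6 percentage points lower from compound 1 to compound 2 (within the scatter) for the one step then known, whereas the new compound also separates from the methylsulfonyl compound, with a number 20 percentage points lower from compound 1 to compound 3 (beyond the scatter) in the same assay. In a physicochemical assay for lipophilicity, at pH 7.4 (on this read-out higher numbers stand for higher lipophilicity and lower numbers for lower lipophilicity), compound 2 gives 2.1 and compound 3 gives 2 with a number 0.10 log units lower from compound 2 to compound 3 (within the scatter) on that read-out, and nothing available here accounts for the lower maximal response of compound 3.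

The compounds shown leave open whether the lower number belongs to 2-methoxyethyl alone or extends to a longer chain such as 3-methoxypropyl. They also leave open how an amine or a carboxylic acid at this same place would compare with the ether and methylsulfonyl groups.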